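Adding a chloro group to the benzyl arm of compound 2

The compounds below may be only part of what the source reports. "The series", "measured", "known", "first", "only" and "open" are said of these compounds alone.

Compound 2, `CC1=C(C(=O)Nc2ccc([N+](=O)[O-])cc2)C(c2ccc(Br)cc2)N=C(SCc2ccccc2)N1`, was tested in a functional assay on the whole organism (artery, strain albino) with Rattus norvegicus as the target, with a stated time of 300 min, at a dose of 10 mg/kg by the oral route (a higher number here means more inhibition at the dose given (going by the name of the read-out), a lower number less inhibition), and gave 29.7%. Compound 1, `CC1=C(C(=O)Nc2ccc(F)cc2)C(c2ccc([N+](=O)[O-])cc2)N=C(SCc2ccccc2)N1`, gives 38.5% in this assay, a number that differs from compound 2 by less than the usual scatter, so the two cannot be ranked against each other. Compound 3, `CC1=C(C(=O)Nc2ccc([N+](=O)[O-])cc2)C(c2ccc(Br)cc2)N=C(SCc2cccc(Cl)c2)N1`, is compound 2 with one change: chloro in place of hydrogen on an aromatic carbon. Among the compounds with values here, no measured pair shows what such a change does here, so the step from compound 2 to compound 3 is expected to stay within the scatter, a number 1.3 percentage points higher from compound 2 to compound 3 (within the scatter). For compound 3 in this assay the estimate is 31%, likely between 12% and 52%.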

Compound 3, a percentage reported as inhibition, in the whole organism at one dose (the size of the read-out at that dose, not a potency): 9.2%
Estimate against measurement, compound 3: 21.8 percentage points above; measured number below the stated range.
By their numbers in this assay, from the lowest: compound 3; then compounds 2 and 1 (each within the scatter of the next).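

Turning benzyl into 3-chlorobenzyl gives a number 20.5 percentage points lower from compound 2 to compound 3 (beyond the scatter) in this assay and so shows that this arm is not indifferent to a single added chlorine atom. Before this step, no measured pair showed what any change on this ring does. No measurement here offers a reason for the drop. The compounds shown leave open whether the loss is specific to chloro or would follow any group at this place. A methoxy group or an amine on the same carbon would help separate those two readings.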